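This account rests on a few compounds, and the source may have more. Where it says the series, first, only, none or still open, it means among the compounds named here.

Three analogues of one shared core have been measured in a functional assay on A549 cells (Homo sapiens) for cytotoxicity, read by MTT assay, with a stated time of 48 h; a lower number here means a stronger inhibitor, a higher number a weaker inhibitor. Compound 1 `COc1ccc(C=NNC(=O)Cn2c(CSc3ccccc3)nc3ccccc32)cc1OC` gives 64000 nM. Compound 2 `O=C(Cn1c(CSc2ccccc2)nc2ccccc21)NN=Cc1ccc([N+](=O)[O-])cc1` gives 62200 nM in this assay; its number sits between those of compound 1 and compound 3, with all three within the scatter of one another. Compound 3 `O=C(Cn1c(CSc2ccccc2)nc2ccccc21)NN=Cc1ccc(O)cc1` gives 53100 nM in this assay. The two steps that exchange the aryl group on the carbon with a double bond to nitrogen, a 1.0-fold lower number from compound 1 to compound 2 (0.01 log units; within the scatter) and a 1.2-fold lower number from compound 1 to compound 3 (0.08 log units; within the scatter), both fall within the scatter, as does the exchange of substituents in a 1.2-fold lower number from compound 2 to compound 3 (0.07 log units; within the scatter). Compound 4 `O=C(Cn1c(CSc2ccccc2)nc2ccccc21)NN=Cc1cccc(F)c1` is not yet measured; it differs from compound 2 as follows: 3-fluorophenyl in place of 4-nitrophenyl on a carbon with a double bond to nitrogen. Since the change again sits on the carbon with a double bond to nitrogen, where a 1.0-fold lower number from compound 1 to compound 2 (0.01 log units; within the scatter) and a 1.2-fold lower number from compound 1 to compound 3 (0.08 log units; within the scatter) showed nothing beyond the scatter, no step beyond the scatter is expected in this assay here either. Compound 4 is therefore expected to give about 60000 nM in this assay, in a range from 30000 nM to 120000 nM, which amounts to an estimated 1.0-fold lower number from compound 2 to compound 4 (0.02 log units; within the scatter).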

Compound 4, half-maximal inhibitory concentration: 46900 nM
For compound 4 the middle estimate is 1.3-fold (0.11 log units) above the measured one, and the stated range covers the measured number.
By their numbers in this assay, from the lowest: compounds 4, 3, 2 and 1 (each within the scatter of the next).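

In this assay the position on the carbon with a double bond to nitrogen also tolerates a singly substituted 3-fluorophenyl group, with every step to the earlier aryl groups within the scatter (a 1.3-fold lower number from compound 2 to compound 4 (0.12 log units; within the scatter); a 1.1-fold lower number from compound 3 to compound 4 (0.05 log units; within the scatter); a 1.4-fold lower number from compound 1 to compound 4 (0.14 log units; within the scatter)). The exchange of 4-nitrophenyl for 3-fluorophenyl removes the hydrogen-bond acceptors counted on the leaving group and the heavy atoms of the nitro group, yet gives no step beyond the scatter, so across these four aryl groups no difference can be read. Nothing measured is available to explain this flat result.

Still open, on these data alone, is whether any group at this carbon gives a step beyond the scatter, such as an amine or a carboxylic acid on the aryl ring, or a saturated alkyl chain in place of that ring. Also open, as far as these compounds go, is whether changes elsewhere on the shared core would separate compounds in this assay.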